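Removing a methyl from the core of compound 1

The source may report more compounds than this note shows. Statements on the series, on what has been measured and on what is new or still open speak of the compounds shown alone.

Compound 1 `COc1ccc([C@@H]2CCc3c(OC)cc(OC)cc3O2)cc1` is the anchor of this small series. In a functional assay on U-937 cells (Homo sapiens) for antiproliferative activity, read by WST assay, with a stated time of 48 h (a lower number here means a stronger inhibitor, a higher number a weaker inhibitor), compound 1 gives 21000 nM. Compound 2 `COc1ccc([C@@H]2CCc3c(OC)cc(OC)cc3O2)c(OC)c1` carries a methoxy in place of hydrogen on an aromatic carbon. For compound 2 the assay returns only a limit, > 100000 nM, not a number. Compound 3 `COc1cc([C@H]2Oc3cc(O)ccc3C(=O)[C@@H]2O)ccc1O` rests on a different core. For compound 3 the assay likewise returns only a limit, > 100000 nM. Among the compounds with values here, compound 1 therefore stands as the only compound with a finite value, since the other two sit at the limit of > 100000 nM in this assay, at which 2 of the 3 values shown sit. Within the data shown here, the single measured step, an at least 4.7-fold higher number from compound 1 to compound 2 (0.67 log units; beyond the scatter), shows that one added methoxy can push a compound out of the measurable range.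

Compound 4 `COc1cc(OC)c2c(c1)O[C@H](c1ccc(O)cc1)CC2` differs from compound 1 by hydrogen in place of methyl on an oxygen on an aromatic ring. Among the measured compounds shown here, no measured step covers this kind of change; the step from compound 1 to compound 2 concerns an added methoxy, not a removed methyl, so it gives no direct guide. The expected step is therefore a 1.1-fold lower number from compound 1 to compound 4 (0.02 log units; within the scatter), within the usual scatter. Compound 4 is estimated at 20000 nM, with a likely range from 7000 nM to 60000 nM.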

Compound 4, half-maximal inhibitory concentration: 40000 nM
Compound 4: the middle estimate sits 2.0-fold (0.30 log units) below what was measured, and the stated range covers the measured number.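

In this assay the step for methoxy to hydroxy, a 1.9-fold higher number from compound 1 to compound 4 (0.28 log units; within the scatter), lies within the scatter, so this change on an oxygen on an aromatic ring cannot be told apart from no change at all. The earlier step, an at least 4.7-fold higher number from compound 1 to compound 2 (0.67 log units; beyond the scatter), showed only that adding a methoxy can cost activity, whereas compound 4 shows that the methyl on this oxygen can go and the compound still gives a finite value rather than a limit. Nothing shown here accounts for why this change has so little effect.

As far as these compounds go, it remains open whether an ethyl or a longer chain on this oxygen, or an amine in place of the hydroxy, would give a similar value. Also open, from the compounds shown here alone, is whether removing the methyl from either methoxy on the shared core would be as small a step.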